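Swapping One Aromatic Ring on a Shared Core

The source may hold more compounds than are shown below. What is called first, only, known or untested is meant among the compounds shown, and "the series" means these compounds.

Compound 1 `Nc1nc(-c2ccc(Cl)cc2)c(CC(=O)O)s1` gives > 100000 nM in an in vitro assay on HEK385-7 cells for displacement of a labelled ligand from prostaglandin D2 receptor 2 (Homo sapiens) (a higher number here means a weaker inhibitor, a lower number a stronger inhibitor), which is a limit of the assay rather than a number.
Compound 2 `O=C(O)Cc1sc(CSc2ccccc2)nc1-c1ccc(Cl)cc1` gives 250 nM in this assay.
Compound 3 `NS(=O)(=O)c1cccc(-c2nc(C(c3ccc(F)cc3)c3ccc(F)cc3)sc2CC(=O)O)c1` gives 140 nM in this assay.

Compound 3 has the lowest of the two numbers shown, but its nearest neighbour, compound 2, sits within the scatter of it, so the two cannot be ranked. Compound 1 stands only at a limit (the limit of > 100000 nM in this assay, at which 1 of the 3 values shown sits).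

Compound 4 `O=C(O)Cc1sc(C(c2ccc(F)cc2)c2ccc(F)cc2)nc1-c1ccnc(Cl)c1` differs from compound 3 in a single place: 2-chloropyridin-4-yl in place of 3-sulfamoylphenyl on an aromatic carbon.

Among the compounds with values here, the only measured step is an at least 400-fold lower number from compound 1 to compound 2 (2.60 log units; beyond the scatter), and that change sits on another carbon of the shared core, so it does not speak to the ring that is swapped here. Compound 2 and compound 3 differ at this ring and elsewhere, and their values lie within the scatter of each other. Within the data shown here, with no step bearing on the change, no shift beyond the scatter is expected.

Compound 4 is therefore estimated at 250 nM, with a range from 80 nM to 1000 nM. The expected step of a 1.8-fold higher number from compound 3 to compound 4 (0.25 log units; within the scatter) stays within the scatter.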

Compound 4, half-maximal inhibitory concentration: 3.1 nM
For compound 4 the middle estimate is 81-fold (1.91 log units) above the measured one; the measured number lies below the stated range.
By their numbers in this assay, from the lowest: compound 4; then compounds 3 and 2 (each within the scatter of the next). At a limit, above all of these: compound 1.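

In this assay, putting 2-chloropyridin-4-yl in place of 3-sulfamoylphenyl gives a 45-fold lower number from compound 3 to compound 4 (1.65 log units; beyond the scatter). Within the data shown here, this is the first measured sign that the ring on this aromatic carbon, next to the ring atom that bears a carboxymethyl group, can move the number far beyond the scatter while the rest of the molecule stays the same. Nothing measured here accounts for the size of this step.

The swap changes several things at once: the sulfamoyl group leaves, while a ring nitrogen and a chlorine enter, so the step cannot be assigned to any one of them. A plain pyridin-4-yl ring or a 2-methylpyridin-4-yl ring at this carbon would be needed to show how much depends on the chlorine and how much on the ring nitrogen.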